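A Dichlorophenyl Swap Where Only Limits Are Known

The source may report more compounds than this note shows. Statements on the series, on what has been measured and on what is new or still open speak of the compounds shown alone.

Two close relatives, compound 1 `C=C[C@@](C)(/C=C/c1ccc(Nc2ccc(F)cc2)cc1)CCC=C(C)C` and compound 2 `C=C[C@@](C)(/C=C/c1ccc(Nc2c(F)cc(F)cc2F)cc1)CCC=C(C)C`, have so far been measured in an ADME assay on HEK293 cells (Homo sapiens) for cytotoxicity, with a stated time of 72 h; a lower number here means that less compound is needed, a higher number that more compound is needed for the effect. Here compound 1 gives > 36600 nM, which is a limit of the assay and not a number. Going by these compounds, compound 2 gives > 36600 nM, which is likewise a limit, so its exact standing is unknown.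

The next structure, compound 3 `C=C[C@@](C)(/C=C/c1ccc(Nc2ccc(Cl)c(Cl)c2)cc1)CCC=C(C)C`, carries 3,4-dichlorophenyl in place of 2,4,6-trifluorophenyl on a nitrogen on an aromatic ring. Within the data shown here, the only measured step that bears on this change is a step that the two limits leave unreadable from compound 1 to compound 2. Its size cannot be read due to the limit of > 36600 nM in this assay, at which 2 of the 2 values shown sit. That step touched the same place in the structure, but it offers no measured size to carry over. The expectation is therefore for no step beyond the scatter, though this is a weakly supported default. The expected change is a number no higher from compound 2 to compound 3 (the limit leaves the size open). A report of only a limit again would be unsurprising. For compound 3 the estimated value in this assay is 36600 nM, with an expected range from 15000 nM to 75000 nM.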

Compound 3, half-maximal effective concentration: > 36600 nM
Compound 3 gave a limit, no number (the forecaster's own chance of this, stated with the estimate: 65%); the middle value lies on the limit itself.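

Compound 1, compound 2 and compound 3 all end at a limit of the assay rather than a number, so no step among them can be read: the limit of > 36600 nM in this assay, at which 3 of the 3 values shown sit.

The compounds shown leave open whether swapping among 4-fluorophenyl, 2,4,6-trifluorophenyl and 3,4-dichlorophenyl changes the concentration needed for the half-maximal effect, and what that concentration is for each compound.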